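One Extra Chain Carbon, on Two Different Cores

The source may hold more compounds than are shown below. What is called first, only, known or untested is meant among the compounds shown, and "the series" means these compounds.

Compound 1, `CCCCOc1ccc(-c2[nH]c3ccccc3c2C2=C(Br)C(=O)NC2=O)cc1`, in a physicochemical assay for lipophilicity; a higher number here means a more lipophilic compound, a lower number a more polar compound: 3.87
Compound 2, `CCCCCOc1ccc(-c2[nH]c3ccccc3c2C2=C(Br)C(=O)NC2=O)cc1`, in this assay: 4.2
Compound 3, `CCCc1cccc2c(C3=C(Br)C(=O)NC3=O)c(-c3ccc(OC)cc3)[nH]c12`, in this assay: 3.58

Compound 2 carries methyl in place of hydrogen on a saturated chain carbon, four bonds along the chain from an oxygen on an aromatic ring, and that single change gave a number 0.33 log units higher from compound 1 to compound 2 (beyond the scatter). Compound 4, `CCCCc1cccc2c(C3=C(Br)C(=O)NC3=O)c(-c3ccc(OC)cc3)[nH]c12`, is not yet measured; it carries methyl in place of hydrogen on a saturated chain carbon, three bonds along the chain from an aromatic carbon. The difference between the core of compound 1 and the core of compound 3 is not broken down here. The two changes are the same kind of change but not the same: in compound 2 the chain hangs from an oxygen on an aromatic ring and the new carbon sits four bonds along it, while in compound 4 the chain hangs from an aromatic carbon and the new carbon sits three bonds along it. In this assay the expected step is a number 0.33 log units higher from compound 3 to compound 4 (beyond the scatter), about the size of the earlier one, because one added chain carbon gave a number 0.33 log units higher from compound 1 to compound 2 (beyond the scatter). Compound 4 is therefore estimated at 3.91, expected between 3.6 and 4.2.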

Compound 4, partition coefficient: 3.81
For compound 4 the middle estimate is 0.10 log units above the measured one, and the stated range covers the measured number.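

In this assay the added carbon on the core of compound 3 gave a number 0.23 log units higher from compound 3 to compound 4 (within the scatter) and so cannot be told apart from repeat-measurement noise, whereas the related change on the core of compound 1 gave a number 0.33 log units higher from compound 1 to compound 2 (beyond the scatter) and stands clear of it. The new step does not rule out that the change carries from one core to the other, but it does not establish it either: each core offers a single pair, and the chain is attached differently in each. Nothing shown here offers an explanation for either step.

Still open, from the compounds shown here alone, is whether a longer chain than butyl on the core of compound 3 would give a step beyond the scatter. Also open, going by these compounds, is how an amine or a carboxylic acid would read in place of that chain.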